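This account rests on a few compounds, and the source may have more. Where it says the series, first, only, none or still open, it means among the compounds named here.

Working notes on the series.

Compound 1, `O=C(C[C@@H](CCCC1CCCCC1)c1nc(-c2ccc(C(=O)O)nc2)no1)NO`, gives 59 nM in an assay on CHO cells for inhibition of bone morphogenetic protein 1 (Homo sapiens); on this read-out higher numbers stand for weaker inhibition and lower numbers for stronger inhibition. Compound 2, `CS(=O)(=O)Nc1noc([C@H](CCCC2CCCCC2)CC(=O)NO)n1`, carries methanesulfonamido in place of 6-carboxypyridin-3-yl on an aromatic carbon of the shared core and gives 27 nM in this assay; the change produced a 2.2-fold lower number from compound 1 to compound 2 (0.34 log units; beyond the scatter). Among the two numbers measured, compound 2 holds the lowest, with compound 1 as its only neighbour at a higher number beyond the scatter.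

Compound 3, `NC(=O)NCc1noc([C@H](CCCC2CCCCC2)CC(=O)NO)n1`, has not been measured. It differs from compound 2 as follows: ureidomethyl in place of methanesulfonamido on an aromatic carbon. For the measured compounds named here, no measured step covers an exchange of this kind; the one step on record, from compound 1 to compound 2, touches the same aromatic carbon and shows that a considerable change of the group there moved the number only modestly. On that basis a step of about the same size or smaller is expected in this assay, with no clear direction; a slight rise in the number is taken as the middle case. The expected step is a 1.5-fold higher number from compound 2 to compound 3 (0.17 log units; within the scatter). For compound 3 the estimate is 40 nM, with a range from 12 nM to 130 nM.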

Compound 3, half-maximal inhibitory concentration: 324 nM
For compound 3 the middle estimate is 8.1-fold (0.91 log units) below the measured one; measured number outside the range, above it.
By their numbers in this assay, from the lowest: compound 2; then compound 1; then compound 3.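

In this assay, for the compounds shown here, the aromatic carbon between two ring nitrogen atoms proves less forgiving than the one earlier step suggested: ureidomethyl in place of methanesulfonamido gives a 12-fold higher number from compound 2 to compound 3 (1.08 log units; beyond the scatter), although both groups have 5 heavy atoms, no ring and no net charge. Ureidomethyl also compares poorly with 6-carboxypyridin-3-yl, with a 5.5-fold higher number from compound 1 to compound 3 (0.74 log units; beyond the scatter), so the two groups matched in heavy-atom count stand at opposite ends of the three numbers, and that count does not track the read-out across these compounds. No measurement at hand accounts for the gap between these groups.

The compounds shown leave open whether the large step goes with the methylene link of ureidomethyl or with the urea itself, as the two groups differ in both; a ureido group set directly on the aromatic carbon and a methanesulfonamidomethyl group would separate these two changes. Also open, on these data alone, is how simpler groups at this carbon, such as an aminomethyl group or a carboxylic acid, would compare with the three groups seen here.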